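The source may report more compounds than this note shows. Statements on the series, on what has been measured and on what is new or still open speak of the compounds shown alone.

Measured so far in a functional assay on MDA-MB-231 cells (Homo sapiens) for antiproliferative activity, read by MTT assay, with a stated time of 72 h; a higher number here means a weaker inhibitor, a lower number a stronger inhibitor:

compound 1 `COc1ccc(NC(=O)c2cc(OC)c(OC)c(OC)c2)cc1[N+](=O)[O-]` gives 31000 nM
compound 2 `COc1ccc(NC(=O)c2cc(OC)c(OC)c(OC)c2)cc1N` gives 18600 nM
compound 3 `COc1ccc(C(=O)Nc2cc(OC)c(OC)c(OC)c2)cc1[N+](=O)[O-]` gives 5700 nM

Compound 1 and compound 2 share one core and differ in a single place: amino in place of nitro on an aromatic carbon. In this assay this change gave a 1.7-fold lower number from compound 1 to compound 2 (0.22 log units; within the scatter), a step that does not separate the two compounds.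

Compound 3 is built from the same atoms as compound 1, joined differently; the difference between the two cores is not broken down here. In this assay compound 3 gives the lowest number of the three measured compounds, and its gaps to compound 2 and to compound 1 both lie beyond the scatter, so on the core of compound 3 the series sits at a stronger level than on the core of compound 1.

Compound 4 `COc1ccc(C(=O)Nc2cc(OC)c(OC)c(OC)c2)cc1N` has not been measured. It stands to compound 3 as compound 2 stands to compound 1: amino in place of nitro on an aromatic carbon. The place of the change reads the same in both pairs, so this is the same change made on the other core. Among the compounds with values here, the only guide to its size is the pair already measured, where compound 1 to compound 2 gave a 1.7-fold lower number from compound 1 to compound 2 (0.22 log units; within the scatter), a step within the scatter. The step from compound 3 to compound 4 is expected to be of similar size, a 1.5-fold lower number from compound 3 to compound 4 (0.18 log units; within the scatter), because in the measured pair the same change gave a 1.7-fold lower number from compound 1 to compound 2 (0.22 log units; within the scatter). Whether the change behaves the same on the core of compound 3 is not shown by any measured compound, so the expected range is kept wide. For compound 4 the estimate in this assay is 3800 nM, with a range from 1400 nM to 10000 nM.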

Compound 4, half-maximal inhibitory concentration: 94200 nM
The estimate for compound 4 lay 25-fold (1.39 log units) below the measured number, outside the stated range (above it).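

In this assay, amino in place of nitro on an aromatic carbon gave a 17-fold higher number from compound 3 to compound 4 (1.22 log units; beyond the scatter) and so produced a large weakening on the core of compound 3, while the same change did not separate the two compounds on the core of compound 1. The size of this change therefore does not carry from one core to the other in this series, and the two steps are clearly distinct: the same change on two cores in this assay, a 1.7-fold lower number (0.22 log units; within the scatter) from compound 1 to compound 2 and a 17-fold higher number (1.22 log units; beyond the scatter) from compound 3 to compound 4, 28-fold (1.44 log units) apart, beyond the scatter of two such steps.
Two pairs do not show which part of the difference between the cores goes with this divergence, nor how the change would behave on any further core.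

On these data alone, it remains open whether the weakening on the core of compound 3 is particular to the amino group or would also appear with another group in the same place, such as a hydroxyl group, a methylamino group or an acetamide. As far as these compounds go, it is also open whether the advantage of compound 3 over compound 1 would survive replacing the methoxy group on the nitro-bearing ring with a longer chain such as ethoxy or propoxy.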